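Trimethylphenyl in Place of Chloromethylphenyl: an Expected Loss

The compounds below may be only part of what the source reports. "The series", "measured", "known", "first", "only" and "open" are said of these compounds alone.

Compound 1 `COc1cc2c(Nc3nc4ccc(C(=O)Nc5c(C)cccc5Cl)cc4s3)ncnc2cc1OCCCN1CCCCC1C`: 6700 nM
Compound 2 `COc1cc2c(Nc3nc4ccc(C(=O)Nc5c(C)cccc5C)cc4s3)ncnc2cc1OCCCN1CCCCC1`: > 100000 nM

Among the compounds with values here, in a functional assay on DLD-1 cells (Homo sapiens) for cytotoxicity, read by WST assay, with a stated time of 72 h (a lower number here means a stronger inhibitor, a higher number a weaker inhibitor), compound 1 gives 6700 nM, the only number reported here. Compound 2 gives > 100000 nM, which is a limit of the assay and not a number (the limit of > 100000 nM in this assay, at which 1 of the 2 values shown sits). Compound 3 `COc1cc2c(Nc3nc4ccc(C(=O)Nc5c(C)cc(C)cc5C)cc4s3)ncnc2cc1OCCCN1CCCCC1C` differs from compound 1 by 2,4,6-trimethylphenyl in place of 2-chloro-6-methylphenyl on an amide-type nitrogen. Within the data shown here, no measured pair differs in this one place, so the size of this step is unknown; compound 1 and compound 2 differ in two places, and their values show only that one is measurable and the other is not. A weakening beyond the scatter is expected, a 4.5-fold higher number from compound 1 to compound 3 (0.65 log units; beyond the scatter). Compound 3 is estimated at 30000 nM, between 8000 nM and 150000 nM.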

Compound 3, half-maximal inhibitory concentration: 5700 nM
Estimate against measurement, compound 3: 5.3-fold (0.72 log units) above, and the stated range ends above it.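

In this assay, 2,4,6-trimethylphenyl in place of 2-chloro-6-methylphenyl on an amide-type nitrogen gives a 1.2-fold lower number from compound 1 to compound 3 (0.07 log units; within the scatter), the first size the compounds show for this change. At this position, then, a group without chlorine reads alike with the chlorine-bearing one in these two compounds. Nothing measured here bears on why the two groups read alike.

Within the data shown here, compound 2 remains a limit of the assay and not a number, so no step to it can be read. Going by these compounds, what a carboxylic acid or an amine on this phenyl ring would do remains open.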